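The compounds below may be only part of what the source reports. "The series", "measured", "known", "first", "only" and "open" are said of these compounds alone.

Of the compounds shown here, three have so far been measured in a physicochemical assay for pharmacokinetics, read by HPLC, in phosphate buffer, at pH 7.4, tested at 100 uM; on this read-out higher numbers stand for a longer-lived compound and lower numbers for a shorter-lived compound. Compound 1 `NC(=O)c1c(CSCC(=O)Oc2ccccc2C(=O)O)no[n+]1[O-]` gives 0.75 h, compound 2 `N#Cc1c(CSCC(=O)Oc2ccccc2C(=O)O)no[n+]1[O-]` gives 0.55 h, and compound 3 `N#Cc1nonc1CSCC(=O)Oc1ccccc1C(=O)O` gives 0.633 h. Compound 1 and compound 2 share a core and differ in one place: carbamoyl in place of cyano on an aromatic carbon. That change made a 1.4-fold higher number from compound 2 to compound 1 (0.13 log units; within the scatter). Compound 2 and compound 3 carry different cores; the difference between the two cores is not broken down here, and the two values lie close together in this assay. Compound 4 `NC(=O)c1nonc1CSCC(=O)Oc1ccccc1C(=O)O` has not yet been measured. It stands to compound 3 as compound 1 stands to compound 2: carbamoyl in place of cyano on an aromatic carbon. This is the same kind of change, though the place is not identical word for word: in compound 2 the carbon that carries the cyano is also next to the ring atom that bears a group of 1 heavy atom, which is not said of compound 3. Because the earlier change gave a 1.4-fold higher number from compound 2 to compound 1 (0.13 log units; within the scatter), a step of similar size is expected here, a 1.3-fold higher number from compound 3 to compound 4 (0.10 log units; within the scatter). Compound 4 is therefore estimated at 0.8 h, with a likely range from 0.5 h to 1.3 h.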

Compound 4, half-life: 0.833 h
For compound 4 the middle estimate is 1.0-fold (0.02 log units) below the measured one, and the stated range covers the measured number.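

In this assay carbamoyl in place of cyano on an aromatic carbon gives a 1.3-fold higher number from compound 3 to compound 4 (0.12 log units; within the scatter) and, on the other core, the same change gives a 1.4-fold higher number from compound 2 to compound 1 (0.13 log units; within the scatter) so the two steps agree closely in size across these two cores. Both steps lie within the usual scatter of repeated measurements, so this agreement does not show that the change truly lengthens the half-life, nor that it would carry over to any further core. Nothing available here explains the two steps.

The compounds shown leave open whether a group such as a carboxylic acid, an amine or a longer chain, placed on that same aromatic carbon, would give a half-life clearly different from those seen with cyano and carbamoyl. They also leave open whether a larger change at this place could produce a step that stands clear of the scatter on both cores.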